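Replacing the 4-methylphenyl of compound 2

The source may hold more compounds than are shown below. What is called first, only, known or untested is meant among the compounds shown, and "the series" means these compounds.

In a functional assay on K562 cells (Homo sapiens) for inhibition, read by trypan blue exclusion, with a stated time of 72 h (a lower number here means a stronger inhibitor, a higher number a weaker inhibitor), compound 1 (`Cn1c(=O)c(S(=O)(=O)c2ccc(Cl)cc2)cc2cnc(Nc3ccc4[nH]ccc4c3)nc21`) gives 100 nM and compound 2 (`Cc1ccc(S(=O)(=O)c2cc3cnc(Nc4ccc5[nH]ccc5c4)nc3n(C)c2=O)cc1`) gives 750 nM as the higher of the two numbers. Compound 3 (`Cn1c(=O)c(S(=O)(=O)c2ccc([N+](=O)[O-])cc2F)cc2cnc(Nc3ccc4[nH]ccc4c3)nc21`) carries 2-fluoro-4-nitrophenyl in place of 4-methylphenyl on a sulfonyl sulfur. Within the data shown here, the one measured step bearing on this change is a 7.5-fold higher number from compound 1 to compound 2 (0.88 log units; beyond the scatter) for methyl in place of chloro on an aromatic carbon, and it lies beyond the scatter. Among the measured compounds shown here, no measured compound carries fluoro or nitro, so that step is only a loose guide. The expected step is a 3.0-fold lower number from compound 2 to compound 3 (0.48 log units; beyond the scatter) in this assay toward a lower number. For compound 3 the estimate is 250 nM with an expected range of 70 nM to 800 nM for this measurement.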

Compound 3, half-maximal inhibitory concentration: 200 nM
Estimate against measurement, compound 3: 1.3-fold (0.10 log units) above; the measured number falls inside the stated range.
By their numbers in this assay, from the lowest: compounds 1 and 3 (each within the scatter of the next); then compound 2.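

In this assay, a phenyl on the sulfonyl sulfur can carry fluoro and nitro together without loss: the change gives a 3.8-fold lower number from compound 2 to compound 3 (0.57 log units; beyond the scatter) for 2-fluoro-4-nitrophenyl in place of 4-methylphenyl. Set against 4-chlorophenyl, the same group gives a 2.0-fold higher number from compound 1 to compound 3 (0.30 log units; within the scatter) and so cannot be told apart from it here, leaving 4-methylphenyl alone at the higher number among the three. No measured evidence bears on the reason for these steps.

Still open, from the compounds shown here alone, is what fluoro and nitro each contribute alone. Also open, going by these compounds, is how an unsubstituted phenyl, an amine or a carboxylic acid would read on this ring.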